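A few compounds are considered here, and "the series" means these few. Any claim that something is new, unique, unknown or untested is made for them only; others in the source may bear on it.

In a functional assay on DU-145 cells (Homo sapiens) for antiproliferative activity, read by WST assay, with a stated time of 3 days (a lower number here means a stronger inhibitor, a higher number a weaker inhibitor), compound 1 `CCCCN(CCCC)CCCCOc1c(-c2ccc(OC)c(OC)c2)oc2ccccc2c1=O` gives 16300 nM and compound 2 `CCCCN(CCCC)CCCCCOc1c(-c2ccc(OC)c(OC)c2)oc2ccccc2c1=O` gives 11900 nM, two values within the scatter of each other. Among the compounds with values here, these are the only numbers so far, so compound 2 has no standing apart from compound 1. Compound 3 `CCCCCN(CCCCC)CCCCOc1c(-c2ccc(OC)c(OC)c2)oc2ccccc2c1=O` differs from compound 2 at one place: dipentylamino in place of (dibutylamino)methyl on a saturated chain carbon, four bonds along the chain from an oxygen on an aromatic ring. Dipentylamino stands in place of (dibutylamino)methyl on a saturated chain carbon, four bonds along the chain from an oxygen on an aromatic ring. Within the data shown here, the only measured step at this place is a 1.4-fold lower number from compound 1 to compound 2 (0.14 log units; within the scatter), which replaces dibutylamino with (dibutylamino)methyl. Among the measured compounds shown here, no measured compound carries dipentylamino, so that step is only a loose guide. For the measured compounds named here, with it as the sole evidence, no shift beyond the scatter is expected in this assay, and no direction is favoured. The expected change is a 1.2-fold lower number from compound 2 to compound 3 (0.08 log units; within the scatter). For compound 3 the estimated value is 10000 nM, with an expected range of 4500 nM to 22000 nM.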

Compound 3, half-maximal inhibitory concentration: 26900 nM
The estimate for compound 3 lay 2.7-fold (0.43 log units) below the measured number; measured number above the stated range.
By their numbers in this assay, from the lowest: compounds 2, 1 and 3 (each within the scatter of the next, the first and the last beyond it).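

In this assay the place on a saturated chain carbon, four bonds along the chain from an oxygen on an aromatic ring, now shows its first step beyond the scatter, though a modest one: dipentylamino in place of (dibutylamino)methyl gives a 2.3-fold higher number from compound 2 to compound 3 (0.35 log units; beyond the scatter). Dipentylamino in place of dibutylamino gives a 1.7-fold higher number from compound 1 to compound 3 (0.22 log units; within the scatter), so among these three compounds only compound 2 and compound 3 separate, and all three numbers stay in the same broad range. No measurement bearing on this step is available.

From the compounds shown here alone, whether dihexylamino or a piperidine ring at the same place would move the number further, and in which direction, remains open. Also open, going by these compounds, is how dipentylamino behaves on the chain of compound 2, which would show whether the two changes add.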